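Hydroxyethyl for oxanyl on the ring nitrogen of compound 3

The source may report more compounds than this note shows. Statements on the series, on what has been measured and on what is new or still open speak of the compounds shown alone.

This account considers three measured compounds and one not yet measured. In an ADME assay on microsomes from liver (Mus musculus, strain CD1) for metabolic stability, read by LC-MS, using NADPH, with a stated time of 60 min (a lower number here means that the compound disappears faster, a higher number that the compound lasts longer), compound 1 `COc1ccc(-c2c(-c3ccc(OC)cc3)n(Cc3ccccc3)c3ncn([C@@H]4CCCC[C@H]4O)c(=N)c23)cc1` gives 0.487 h. In the same assay compound 2 `N=c1c2c(-c3ccccc3)c(-c3ccccc3)n(Cc3ccccc3)c2ncn1CCCN1CCN(c2ccccc2)CC1` gives 0.233 h. Compound 3 `N=c1c2c(-c3ccccc3)cn(Cc3ccccc3)c2ncn1C1CCOCC1` gives 0.0867 h in this assay, the lowest of the three numbers; the nearest is compound 2, whose number is higher by an amount beyond the usual scatter, and the furthest is compound 1, also beyond the scatter.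

Compound 4 `N=c1c2c(-c3ccccc3)cn(Cc3ccccc3)c2ncn1CCO` differs from compound 3 in one place: 2-hydroxyethyl in place of oxan-4-yl on an aromatic nitrogen. Among the compounds with values here, no step between two measured compounds isolates this kind of change, so the expectation rests on compound 3 alone. In this assay the step from compound 3 to compound 4 is expected to be small, with no clear direction beyond the scatter, as a 1.2-fold higher number from compound 3 to compound 4 (0.06 log units; within the scatter) expresses. Compound 4 is therefore estimated at 0.1 h, within a range from 0.045 h to 0.22 h.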

Compound 4, half-life: 0.153 h
The estimate for compound 4 lay 1.5-fold (0.18 log units) below the measured number, within the range that was stated.
By their numbers in this assay, from the lowest: compounds 3, 4 and 2 (each within the scatter of the next, the first and the last beyond it); then compound 1.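

In this assay, within the data shown here, the step at this aromatic nitrogen, 2-hydroxyethyl in place of oxan-4-yl, is a 1.8-fold higher number from compound 3 to compound 4 (0.25 log units; within the scatter), the first step in this set that isolates a single place. On this core, the six-membered non-aromatic ring with its hydrogen-bond acceptor can thus give way to an open chain that adds a hydrogen-bond donor without taking the half-life beyond the scatter. No measurement here bears on what lies behind this step.

On these data alone, it remains open how a longer chain such as 3-hydroxypropyl, or a carboxylic acid such as carboxymethyl, would behave on this nitrogen. As far as these compounds go, it is equally open whether 2-hydroxyethyl would give a similar step on a core carrying a second phenyl group, as in compound 2.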